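A few compounds are considered here, and "the series" means these few. Any claim that something is new, unique, unknown or untested is made for them only; others in the source may bear on it.

Working notes on the acylguanidine series.

Three compounds of the shared core have numbers in a functional assay for inhibition of sodium/hydrogen exchanger (Oryctolagus cuniculus); a higher number here means a weaker inhibitor, a lower number a stronger inhibitor. Compound 1 `Cc1c(C(=O)N=C(N)N)cc(S(C)(=O)=O)c(Cl)c1Cl` gives 29 nM in this assay. Compound 2 `CCCc1cc(C)c(C(=O)N=C(N)N)cc1S(C)(=O)=O` gives 5.7 nM. Compound 3 `Cc1cc(Br)c(C(=O)N=C(N)N)cc1S(C)(=O)=O` gives 70 nM. Compound 2 thus has the lowest number of the three, with compound 1 nearest and compound 3 furthest; both gaps lie beyond the usual scatter, so compound 2 is the strongest inhibitor measured so far.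

Compound 4 `Cc1cc(Sc2ccccc2Cl)c(S(C)(=O)=O)cc1C(=O)N=C(N)N` has not been measured in this assay. It differs from compound 2 in one place: (2-chlorophenyl)sulfanyl in place of propyl on an aromatic carbon. The propyl chain that leaves and the (2-chlorophenyl)sulfanyl group that enters sit on the same aromatic carbon, ortho to the methylsulfonyl group and para to the acylguanidine side.

Within the data shown here, no measured pair shows what such a change does here, so the expectation rests only on compound 2 and its value 5.7 nM. A moderate weakening is expected, a 2.6-fold higher number from compound 2 to compound 4 (0.42 log units; beyond the scatter), with a wide range on either side. Compound 4 is therefore estimated at 15 nM, between 4 nM and 60 nM.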

Compound 4, half-maximal inhibitory concentration: 14 nM
Beside the measured number, compound 4's estimate is 1.1-fold (0.03 log units) above it; low and high end bracket the measured number.
By their numbers in this assay, from the lowest: compound 2; then compound 4; then compound 1; then compound 3.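

In this assay, (2-chlorophenyl)sulfanyl in place of propyl on the aromatic carbon ortho to the methylsulfonyl group gives a 2.5-fold higher number from compound 2 to compound 4 (0.39 log units; beyond the scatter) as a modest step. This carbon therefore carries a group of 8 heavy atoms with a six-membered aromatic ring in place of a chain of 3 carbons, and compound 4 still gives 14 nM as its value. Nothing available accounts for the size of this step.

From the compounds shown here alone, it remains open whether the step belongs to the sulfur link, the ring or the chlorine; phenylsulfanyl, (2-chlorophenyl)oxy or benzyl on the same carbon would separate these parts. Going by these compounds, how an amine or a carboxylic acid on this carbon would read also remains open.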